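This account rests on a few compounds, and the source may have more. Where it says the series, first, only, none or still open, it means among the compounds named here.

Compound 1 `O=C(N/N=C/c1ccc(CSc2nc3ccccc3o2)cc1)c1ccncc1` and compound 2 `O=C(N/N=C/c1ccc(CSc2nc3ccccc3s2)cc1)c1ccncc1` share one core and differ only in the ring system attached to the sulfur. In an ADME assay on microsomes from liver (Homo sapiens) for metabolic stability, read by LC-MS, with a stated time of 30 min (a higher number here means that more of the compound is left, a lower number that less of the compound is left), compound 1 gives 76.5%. Measured the same way, compound 2 gives 57.2%. That single swap produced a number 19.3 percentage points lower from compound 1 to compound 2 (beyond the scatter). Among the two measured compounds, compound 2 therefore stands lowest, with compound 1 as its only neighbour and higher by more than the scatter.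

Compound 3 `O=C(N/N=C/c1ccc(CSc2nc3ccccc3[nH]2)cc1)c1ccncc1` has not yet been measured in this assay. It differs from compound 2 by 1H-benzimidazol-2-yl in place of 1,3-benzothiazol-2-yl on a sulfur. Among the compounds with values here, only one measured step bears on this change, the one running from compound 1 to compound 2, which altered the same ring system on the same sulfur and was modest in size. A step of similar size is expected here, though a single step cannot fix the direction, so the expected step is a number 4.8 percentage points higher from compound 2 to compound 3 (within the scatter). Compound 3 is estimated at 62%, with a range from 42% to 80%.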

Compound 3, percent of the compound remaining: 62%
The estimate for compound 3 equals the measured number at the digits printed; measured number inside the range.
By their numbers in this assay, from the lowest: compounds 2 and 3 (each within the scatter of the next); then compound 1.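

Swapping 1,3-benzothiazol-2-yl for 1H-benzimidazol-2-yl gives a number 4.8 percentage points higher from compound 2 to compound 3 (within the scatter) in this assay so these two groups on the sulfur cannot be told apart here, although only 1H-benzimidazol-2-yl brings a hydrogen-bond donor. Going the other way from the first compound, 1H-benzimidazol-2-yl in place of 1,3-benzoxazol-2-yl gives a number 14.5 percentage points lower from compound 1 to compound 3 (beyond the scatter) so among these three groups, 1,3-benzoxazol-2-yl alone stands apart from the other two. Nothing available here explains this pattern.

From the compounds shown here alone, it remains open how a simple phenyl or pyridine ring on the sulfur would compare with these fused ring systems. Also open, going by these compounds, is what a methyl group or an amine added to the 1H-benzimidazol-2-yl ring would do to the percent of compound remaining.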